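This account rests on a few compounds, and the source may have more. Where it says the series, first, only, none or still open, it means among the compounds named here.

In a functional assay on MDA-MB-231 cells (Homo sapiens) for antiproliferative activity, read by MTT assay, with a stated time of 72 h (on this read-out higher numbers stand for weaker inhibition and lower numbers for stronger inhibition), compound 1 (`C#Cc1cccc(NC(=O)CCc2cccc3c2B(O)OC3)c1`) gives 1600 nM and compound 2 (`O=C(CCc1cccc2c1B(O)OC2)Nc1cccc(-c2cccc(OC(F)(F)F)c2)c1`) gives 460 nM. Compound 2 therefore holds the lower of the two numbers, and its gap to compound 1 lies beyond the usual scatter. Going by the values given here, the two compounds do not differ in one place only, so no measured step bears directly on the next change. Compound 3 (`CSc1cccc(-c2cccc(NC(=O)CCc3cccc4c3B(O)OC4)c2)c1`), not yet measured, has methylsulfanyl in place of trifluoromethoxy on an aromatic carbon, meta to a large group: methylsulfanyl in place of trifluoromethoxy on an aromatic carbon. Among the compounds with values here, with no direct precedent, the working expectation in this assay is a step no larger than the scatter, with no firm direction, and the starting point is compound 2 at 460 nM. The estimated change is a 1.1-fold higher number from compound 2 to compound 3 (0.05 log units; within the scatter). For compound 3 the estimated value is 520 nM, with an expected range of 230 nM to 1200 nM.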

Compound 3, half-maximal inhibitory concentration: 150 nM
Compound 3: the middle estimate sits 3.5-fold (0.54 log units) above what was measured, and the stated range ends above it.
By their numbers in this assay, from the lowest: compound 3; then compound 2; then compound 1.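

Working notes: this position on the six-membered aromatic ring of carbon only, meta to a large group, is sensitive to the substituent in this assay, since methylsulfanyl in place of trifluoromethoxy gives a 3.1-fold lower number from compound 2 to compound 3 (0.49 log units; beyond the scatter) and the step lies beyond the scatter. The gain comes with the smaller substituent by count, with 2 heavy atoms entering and 5 leaving, so a larger substituent is not required here for the lower number. Replacing ethynyl with 3-(methylsulfanyl)phenyl gives an 11-fold lower number from compound 1 to compound 3 (1.03 log units; beyond the scatter), but no measurement here accounts for either step.

Still open, going by these compounds, is whether a methoxy or an ethyl group at this place would hold the value of compound 3 or lose it. Also open, on these data alone, is how an amine or a carboxylic acid on the same ring would read in this assay.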